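A five-membered ring exchanged in compound 3

The source may report more compounds than this note shows. Statements on the series, on what has been measured and on what is new or still open speak of the compounds shown alone.

Measured in an in vitro ADME assay on microsomes from liver (Homo sapiens) for metabolic stability; a lower number here means slower removal, a higher number faster removal of the compound (both values are limits):
- Compound 1 `Cc1cc(Cn2c(=O)[nH]c3c(N)nc(C(F)(F)F)cc32)no1` gives < 8 mL.min-1.g-1 as a limit
- Compound 2 `Cc1nc(Cn2c(=O)[nH]c3c(N)nc(C(F)(F)F)cc32)cs1` gives < 7 mL.min-1.g-1 as a limit

Going by these compounds, the reading of < 7 mL.min-1.g-1 for compound 2 is a limit and not a number, so its exact place on the scale stays unknown. In compound 3 `Cc1nc(Cn2c(=O)[nH]c3c(N)nc(C(F)(F)F)cc32)co1` a 2-methyl-1,3-oxazol-4-yl group stands in place of 2-methyl-1,3-thiazol-4-yl on a saturated chain carbon bound to an aromatic nitrogen (2-methyl-1,3-oxazol-4-yl in place of 2-methyl-1,3-thiazol-4-yl on a saturated chain carbon bound to an aromatic nitrogen). For the measured compounds named here, since the only measured step bearing on this is a step that the two limits leave unreadable from compound 1 to compound 2 and no size can be read from it, no step beyond the usual scatter is expected in this assay for this exchange. The expected change is a step that the limit leaves unreadable from compound 2 to compound 3 and it remains an estimate. For compound 3 the estimated value is 6 mL.min-1.g-1 with an expected range from 3 mL.min-1.g-1 to 11 mL.min-1.g-1 and a reading that is again only a limit is quite likely.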

Compound 3, intrinsic clearance in microsomes in the Homo sapiens assay: < 8 mL.min-1.g-1
Compound 3 gave a limit, no number (the forecaster's own chance of this, stated with the estimate: 70%); the middle value does not contradict the limit.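

In the Homo sapiens assay compound 1 gives < 8 mL.min-1.g-1 as a limit. In the Homo sapiens assay compound 2 gives < 7 mL.min-1.g-1 as a limit. In the Homo sapiens assay compound 3 gives < 8 mL.min-1.g-1 as a limit. For the compounds shown here, all three are limits rather than numbers, so no step among them can be read. Going by these compounds, how fast each compound is actually removed stays open, as does whether exchanging these five-membered rings changes that rate. In a physicochemical assay for lipophilicity, measured as octanol-water partition, at pH 7.4 (on this read-out lower numbers stand for lower lipophilicity and higher numbers for higher lipophilicity), compound 2 gives 2.3 and compound 3 gives 1.7 as measured numbers, which is a number 0.60 log units lower from compound 2 to compound 3 (beyond the scatter) with 2-methyl-1,3-oxazol-4-yl in place of 2-methyl-1,3-thiazol-4-yl.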